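The source may report more compounds than this note shows. Statements on the series, on what has been measured and on what is new or still open speak of the compounds shown alone.

Compound 1 `CC1=CC[C@@H]([C@@](C)(O)CCCC(C)(C)NC=S)CC1` gives 16700 nM in a functional assay on K562 cells (Homo sapiens) for cytotoxicity, read by sulforhodamine B assay; a lower number here means a stronger inhibitor of growth, a higher number a weaker inhibitor of growth. Compound 2 `COc1ccc(/C=N\NC(=S)NC(C)(C)CCC[C@](C)(O)[C@@H]2CC=C(C)CC2)cc1` gives 220 nM in this assay, and compound 3 `CC1=CC[C@@H]([C@@](C)(O)CCCC(C)(C)NC(=S)N/N=C\c2ccc(N(C)C)cc2)CC1` gives 80 nM in this assay, the lowest of the three numbers. Going by the values given here, the step of a 2.8-fold lower number from compound 2 to compound 3 (0.44 log units; beyond the scatter) is the only measured change on the aromatic ring. Compound 4 `CC1=CC[C@@H]([C@@](C)(O)CCCC(C)(C)NC(=S)N/N=C\c2ccccc2Cl)CC1` differs from compound 3 by 2-chlorophenyl in place of 4-(dimethylamino)phenyl on a carbon with a double bond to nitrogen. Among the compounds with values here, only that one measured step bears on this change, and it was modest, so the new ring is expected to land within a similar distance of compound 3, more likely toward a higher number because compound 2 gave 220 nM with a different group on the same ring. The expected step is a 3.1-fold higher number from compound 3 to compound 4 (0.49 log units; beyond the scatter). Compound 4 is estimated at 250 nM, between 80 nM and 800 nM.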

Compound 4, concentration for 50% growth inhibition: 150 nM
For compound 4 the middle estimate is 1.7-fold (0.22 log units) above the measured one; low and high end bracket the measured number.
By their numbers in this assay, from the lowest: compounds 3, 4 and 2 (each within the scatter of the next, the first and the last beyond it); then compound 1.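

In this assay, 2-chlorophenyl on a carbon with a double bond to nitrogen gives a 1.9-fold higher number from compound 3 to compound 4 (0.27 log units; within the scatter) and a 1.5-fold lower number from compound 2 to compound 4 (0.17 log units; within the scatter). Compound 4 thus sits within the scatter of both earlier compounds, so this position accepts a ring carrying chlorine, with no hydrogen-bond acceptor, as well as rings carrying dimethylamino or methoxy. No measurement here explains why these rings give such similar numbers. Still open, on these data alone, is how an unsubstituted phenyl, a pyridine ring, or a ring carrying a carboxylic acid would compare.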